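A few compounds are considered here, and "the series" means these few. Any claim that something is new, unique, unknown or untested is made for them only; others in the source may bear on it.

Measured compounds:
compound 1, `COc1cc(CN(C(=O)Nc2ccc(C#N)cc2)n2cnnc2)cc(OC)c1OC`, 20700 nM
compound 2, `O=C(Nc1ccccc1)N(Cc1ccccn1)n1cnnc1`, 24900 nM

In a functional assay on A549 cells (Homo sapiens) for cytotoxicity, read by MTT assay, with a stated time of 48 h (on this read-out higher numbers stand for weaker inhibition and lower numbers for stronger inhibition), compound 2 gives 24900 nM, the higher of the two numbers, while compound 1 gives 20700 nM; the two lie within the scatter of each other, so no order between them can be read. Compound 3 is `CC1CCC(NC(=O)N(Cc2ccccn2)n2cnnc2)CC1`, and it differs from compound 2 by 4-methylcyclohexyl in place of phenyl on an amide-type nitrogen. Among the measured compounds shown here, no measured pair shows what such a change does here, so the step from compound 2 to compound 3 is expected to stay within the scatter, with a weak lean towards a higher number, as a 1.3-fold higher number from compound 2 to compound 3 (0.11 log units; within the scatter). Compound 3 is thus estimated at 32000 nM, between 10000 nM and 100000 nM.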

Compound 3, half-maximal inhibitory concentration: 43700 nM
Beside the measured number, compound 3's estimate is 1.4-fold (0.14 log units) below it; the measured number falls inside the stated range.
By their numbers in this assay, from the lowest: compounds 1, 2 and 3 (each within the scatter of the next, the first and the last beyond it).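

In this assay, 4-methylcyclohexyl in place of phenyl on an amide-type nitrogen gives a 1.8-fold higher number from compound 2 to compound 3 (0.24 log units; within the scatter). Among the compounds shown here, this is the first step read at this position, and it shows that a non-aromatic ring of carbon only can stand where the aromatic ring stood without the number leaving the scatter. No measurement on hand offers a reason for this step. The compounds shown leave open whether an amine or a carboxylic acid on this ring would move the number beyond the scatter. They also leave open what a longer chain in place of the ring would do.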